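This account rests on a few compounds, and the source may have more. Where it says the series, first, only, none or still open, it means among the compounds named here.

Compound 1 `O=C(N/N=C/c1ccc(-c2ccc(Cl)cc2)o1)c1ccccc1` gives 19.4% in a functional assay on BGC-823 cells (Homo sapiens) for inhibition, read by sulforhodamine B assay, with a stated time of 48 h, tested at 10 uM; on this read-out higher numbers stand for more inhibition of growth at the one concentration tested and lower numbers for less inhibition of growth.
Compound 2 `O=C(N/N=C/c1ccc(-c2ccc(F)cc2F)o1)c1ccccc1O` gives 68.4% in this assay.

Compound 2 stands highest of the two numbers; its nearest neighbour is compound 1, a gap beyond the usual scatter, though the two differ in more than one place, so only their values can be set side by side. Compound 3 `O=C(N/N=C/c1ccc(-c2ccc(F)cc2)o1)c1ccccc1O` follows from compound 2 by a single change: hydrogen in place of fluoro on an aromatic carbon. Going by the values given here, no one-place step between measured compounds is known, so the size of this step in this assay cannot be read from earlier data; a modest loss is expected, estimated at a number 10.4 percentage points lower from compound 2 to compound 3 (beyond the scatter). Compound 3 is expected to give 58%, within 35% to 80%.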

Compound 3, percent growth inhibition at one concentration: 71.5%
Beside the measured number, compound 3's estimate is 13.5 percentage points below it, within the range that was stated.
By their numbers in this assay, from the lowest: compound 1; then compounds 2 and 3 (each within the scatter of the next).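

Replacing 2,4-difluorophenyl with 4-fluorophenyl, the first one-place step available here, gives a number 3.1 percentage points higher from compound 2 to compound 3 (within the scatter) in this assay. At this position, ortho to a large group, the fluoro is therefore not required for growth inhibition at the one concentration tested, since hydrogen serves as well on this read-out. Nothing at hand gives a reason for this result.

On these data alone, what remains open is how a chloro, a methoxy or an amine at this position would read. Also open, as far as these compounds go, is what hydrogen in place of the remaining fluoro would do.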